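Cyano in Place of Fluoro: An Expected Cell Potency

The source may report more compounds than this note shows. Statements on the series, on what has been measured and on what is new or still open speak of the compounds shown alone.

Compound 1, `CCOC(=O)c1ccc(NC(=O)CCc2cccc3c2B(O)OC3)cc1`: > 100000 nM in this assay, a limit rather than a number.
Compound 2, `O=C(CCc1cccc2c1B(O)OC2)Nc1cccc(-c2ccc(F)cc2)c1`: 550 nM.

The two measured compounds share one core and differ only in the group carried on the amide nitrogen. In a functional assay on HCT-116 cells (Homo sapiens) for antiproliferative activity, read by MTT assay, with a stated time of 72 h (a lower number here means a stronger inhibitor, a higher number a weaker inhibitor), compound 1 reaches only the assay limit of > 100000 nM, which is a limit and not a measured number (the limit of > 100000 nM in this assay, at which 1 of the 2 values shown sits). Among the compounds with values here, compound 2 gives 550 nM in this assay, the single real number among the values shown, so it stands alone as the reference point. Compound 3, `N#Cc1ccc(-c2cccc(NC(=O)CCc3cccc4c3B(O)OC4)c2)cc1`, has not yet been measured. Its change from compound 2 is cyano in place of fluoro on an aromatic carbon. Within the data shown here, no step between two measured compounds is available, so the size of this change cannot be read from the data. The step of a 1.1-fold higher number from compound 2 to compound 3 (0.04 log units; within the scatter) is expected to stay within the usual scatter. Compound 3 is therefore estimated at 600 nM in this assay, with a range from 200 nM to 2000 nM.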

Compound 3, half-maximal inhibitory concentration: 410 nM
The estimate for compound 3 lay 1.5-fold (0.17 log units) above the measured number; the measured number falls inside the stated range.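

Putting cyano in place of fluoro on the aromatic carbon gives a 1.3-fold lower number from compound 2 to compound 3 (0.13 log units; within the scatter) in this assay. Within the data shown here, this is the first step that can be read at this position, para to a large group, and it shows that 4-fluorophenyl and 4-cyanophenyl read alike here, even though the change swaps one heavy atom for two and adds a hydrogen-bond acceptor. Nothing measured here gives a reason for this result.

On these data alone, whether the same position would accept a very different group, such as an amine, a carboxylic acid or a longer chain, remains open. Also open, as far as these compounds go, is whether a plain phenyl, with only hydrogen at this position, would read the same, since a single step cannot show how far this result extends.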